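Swapping the para group on a shared core

The source may hold more compounds than are shown below. What is called first, only, known or untested is meant among the compounds shown, and "the series" means these compounds.

Compound 1 `Cc1cnc(Nc2ccc(C(C)C)cc2)nc1Nc1nc2ccccc2s1` in a functional assay on HCT-116 cells (Homo sapiens) for antiproliferative activity, read by MTT assay, with a stated time of 48 h (a higher number here means a weaker inhibitor, a lower number a stronger inhibitor), gives > 50000 nM, a limit of the assay rather than a number.
Compound 2 `Cc1cnc(Nc2ccc([N+](=O)[O-])cc2)nc1Nc1nc2ccccc2s1` gives 6330 nM.
Compound 3 `Cc1cnc(Nc2ccc(S(N)(=O)=O)cc2)nc1Nc1nc2ccccc2s1` gives 1660 nM.

Compound 3 stands lowest of the two numbers, with compound 2 nearest, a 3.8-fold lower number from compound 2 to compound 3 (0.58 log units; beyond the scatter). The unmeasured compound 4 `Cc1cnc(Nc2ccc(Cl)cc2)nc1Nc1nc2ccccc2s1` differs from compound 3 by chloro in place of sulfamoyl on an aromatic carbon. Both measured steps bear on this change: an at least 30-fold lower number from compound 1 to compound 3 (1.47 log units; beyond the scatter) and a 3.8-fold lower number from compound 2 to compound 3 (0.58 log units; beyond the scatter), and each time the sulfamoyl gave the lower number. Taking the sulfamoyl away is therefore expected to raise the number, probably a step like a 9.0-fold higher number from compound 3 to compound 4 (0.96 log units; beyond the scatter), though chloro is unlike either group replaced. Compound 4 is estimated at 15000 nM, within a range from 4000 nM to 50000 nM.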

Compound 4, half-maximal inhibitory concentration: > 50000 nM
Compound 4 was reported as a limit; the forecaster's own chance of this, stated with the estimate: 25%; middle value at least 3.3-fold (0.52 log units) away from the limit.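

Chloro on this aromatic carbon gives an at least 30-fold higher number from compound 3 to compound 4 (1.47 log units; beyond the scatter) and an at least 7.8-fold higher number from compound 2 to compound 4 (0.89 log units; beyond the scatter). Small chloro therefore joins isopropyl without a readable number, so among the four groups shown, only sulfamoyl and nitro give one. Compound 4 is a limit of the assay rather than a number, and the step from compound 1 to compound 4 cannot be read: the limit of > 50000 nM in this assay, at which 2 of the 4 values shown sit.

The compounds shown leave open how an amine or a carboxylic acid would read at this place. They also leave open whether any group here would give a lower number than sulfamoyl.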